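A few compounds are considered here, and "the series" means these few. Any claim that something is new, unique, unknown or untested is made for them only; others in the source may bear on it.

Compound 1 (`CC(C)C1=C(C(=O)N2[C@H](C)CC[C@H]2C(=O)N2CCN(C)C3(CC3)C2)SC2=N[C@@](C)(c3ccc(Cl)cc3)[C@@H](c3ccc(Cl)cc3)N21`): 41%
Compound 2 (`CC(C)C1=C(C(=O)N2[C@H](C)CC[C@H]2C(=O)N2CCNC3(CC3)C2)SC2=N[C@@](C)(c3ccc(Cl)cc3)[C@@H](c3ccc(Cl)cc3)N21`): 87%

Among the measured compounds shown here, both numbers come from an ADME assay on microsomes from liver (Mus musculus) for metabolic stability, read by LC-MS, with a stated time of 30 min, tested at 1 uM (on this read-out lower numbers stand for a less stable compound and higher numbers for a more stable compound), and are the only measurements so far. Compound 2 stands at 87% and holds the higher of the two numbers. For the measured compounds named here, the one measured step is a number 46 percentage points higher from compound 1 to compound 2 (beyond the scatter) and it came with hydrogen in place of methyl on an amine nitrogen in a ring.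

Compound 3 (`CC(C)C1=C(C(=O)N2[C@H](C)CC[C@H]2C(=O)N2CCNC3(CC3)C2)SC2=N[C@@](C)(c3ccc(Cl)cc3)[C@@H](c3ccc(Cl)c(F)c3)N21`) differs from compound 2 in one place (fluoro in place of hydrogen on an aromatic carbon) where 4-chlorophenyl becomes 4-chloro-3-fluorophenyl, with fluoro in place of hydrogen on an aromatic carbon, ortho to a chloro group. Going by the values given here, the measured step is large, yet it concerns a different part of the molecule, so no measured step speaks directly to this change. A single pair shows no trend either. With compound 2 at 87% little room remains upward in this assay and a modest fall cannot be ruled out. The estimated step is a number 5 percentage points lower from compound 2 to compound 3 (within the scatter) and so no change beyond the scatter is expected. For compound 3 the estimated value is 82% with an expected range from 65% to 95% on this read-out.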

Compound 3, percent of the compound remaining in the Mus musculus assay: 85%
Beside the measured number, compound 3's estimate is 3 percentage points below it; the measured number falls inside the stated range.
By their numbers in the Mus musculus assay, from the lowest: compound 1; then compounds 3 and 2 (each within the scatter of the next).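

In the Mus musculus assay, the move from 4-chlorophenyl to 4-chloro-3-fluorophenyl gives a number 2 percentage points lower from compound 2 to compound 3 (within the scatter), so this aromatic carbon, ortho to a chloro group, can carry a fluoro without any shift beyond the usual scatter, and the high stability seen with the free ring amine is kept, with compound 2 at 87% and compound 3 at 85%. Among the compounds shown here, the earlier pair spoke only about the amine nitrogen, while this pair is the first to test the aromatic ring, and a physicochemical assay for solubility, read by HPLC, in phosphate buffer, at pH 6.8, tested at 10 mM (a higher number here means a more soluble compound, a lower number a less soluble compound), covers the same change, with compound 2 at 56 ug/mL and compound 3 at 51 ug/mL, which is a 1.1-fold lower number from compound 2 to compound 3 (0.04 log units; within the scatter), so neither property moves beyond the scatter. No independent information is available on why the two read-outs behave this way.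

On these data alone, these compounds cover only one small atom at one aromatic carbon, so it remains open whether a larger or different group there, such as a methoxy or a nitrile, would be tolerated as well. As far as these compounds go, it is also open whether a fluoro on the other 4-chlorophenyl group, or the same fluoro combined with the methyl on the ring amine nitrogen, would give a similar result.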